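Adding a Second Chloro to the Core of Compound 3

The source may hold more compounds than are shown below. What is called first, only, known or untested is meant among the compounds shown, and "the series" means these compounds.

Of the compounds shown here, three have so far been measured in a functional assay on ACHN cells (Homo sapiens) for cytotoxicity, read by sulforhodamine B assay, with a stated time of 48 h; on this read-out higher numbers stand for lower toxicity in this test and lower numbers for higher toxicity in this test. Compound 3 `ClCc1ccccc1Cn1cnc2ncnc(Cl)c21` gives 9120 nM, the highest of the three numbers. Compound 2 `ClCc1cccc(Cn2cnc3c(Cl)ncnc32)c1` gives 8120 nM, which lies within the usual scatter of the number for compound 3. Compound 1 `ClCc1ccccc1Cn1cnc2c(Cl)nc(Cl)nc21`, whose core carries two chloro groups, gives 4160 nM, a number lower than that of compound 3 by more than the scatter. Compound 4 `ClCc1ccccc1Cn1cnc2nc(Cl)nc(Cl)c21` has not been measured; it differs from compound 3 by chloro in place of hydrogen on an aromatic carbon. Compound 1, also carrying two chloro groups on its core, gives 4160 nM, and this guides the expectation. The expected step is a 1.9-fold lower number from compound 3 to compound 4 (0.28 log units; within the scatter), toward a lower number in this assay. Compound 4 is estimated at 4800 nM, within a range from 2000 nM to 12000 nM.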

Compound 4, concentration lethal to 50% of the cells: 3540 nM
The estimate for compound 4 lay 1.4-fold (0.13 log units) above the measured number; low and high end bracket the measured number.
By their numbers in this assay, from the lowest: compounds 4, 1, 2 and 3 (each within the scatter of the next, the first and the last beyond it).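

Chloro in place of hydrogen on this aromatic carbon, between two ring nitrogen atoms, gives a 2.6-fold lower number from compound 3 to compound 4 (0.41 log units; beyond the scatter) in this assay. Among the compounds shown here, this is the first step between compounds differing in one place, and it shows that this position can change the number by more than the usual scatter, toward higher toxicity in this test. No measurement here explains the change.

On these data alone, whether an amine or a methoxy group on this carbon would shift the number as chloro does remains open. So does the effect of fluoro there.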